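Notes on the benzyl amide change to compound 4

This account rests on a few compounds, and the source may have more. Where it says the series, first, only, none or still open, it means among the compounds named here.

Within the data shown here, compound 1 `COc1ccc(CNC(=O)/C=C/c2coc3cc(OC)ccc3c2=O)cc1` gives 7570 nM in a functional assay on Huh-7 cells (Homo sapiens) for inhibition, read by MTT assay, with a stated time of 48 h (on this read-out higher numbers stand for weaker inhibition and lower numbers for stronger inhibition), the lower of the two numbers read so far. Compound 2 `COc1ccc(CNC(=O)/C=C/c2coc3cc(O)ccc3c2=O)cc1`, which carries hydrogen in place of methyl on an oxygen on an aromatic ring, gives 8430 nM in this assay, and the step of a 1.1-fold higher number from compound 1 to compound 2 (0.05 log units; within the scatter) is within the scatter. Compound 3 `COc1ccc(NC(=O)/C=C/c2coc3cc(O)ccc3c2=O)cc1` is recorded only as a limit of the assay, > 100000 nM; this is the limit of > 100000 nM in this assay, at which 1 of the 3 values shown sits.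

Compound 4 `COc1ccc2c(=O)c(/C=C/C(=O)NCc3ccc(F)cc3F)coc2c1` differs from compound 1 by 2,4-difluorophenyl in place of 4-methoxyphenyl on a saturated chain carbon bound to an amide-type nitrogen. Among the measured compounds shown here, no measured step touches this part of the molecule: the single step read so far alters the core and not the benzyl amide, so nothing measured sets the size or the direction of the step to compound 4. The expectation is therefore a step no larger than the scatter, with a wide allowance on either side. Compound 4 is estimated at 9000 nM in this assay, with a range of 3000 nM to 27000 nM. The expected step is a 1.2-fold higher number from compound 1 to compound 4 (0.08 log units; within the scatter).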

Compound 4, half-maximal inhibitory concentration: > 100000 nM
Compound 4 ended at the assay's limit (the forecaster's own chance of this, stated with the estimate: 10%); middle value at least 11-fold (1.04 log units) away from the limit.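

Among these compounds, this position on the benzyl amide is not silent: the only earlier step, on the core, stayed within the scatter, while 2,4-difluorophenyl in place of 4-methoxyphenyl on a saturated chain carbon bound to an amide-type nitrogen gives an at least 13-fold higher number from compound 1 to compound 4 (1.12 log units; beyond the scatter) in this assay and counts as a large step. Compound 4 stands at > 100000 nM as a limit of the assay and not a number, and the full size of the step stays unread. The limit now holds a second compound of the series: the limit of > 100000 nM in this assay, at which 2 of the 4 values shown sit.

Still open, going by these compounds, is whether phenyl or 4-fluorophenyl in the same place would stay near compound 1 or also reach the limit. Also open, on these data alone, is whether the same change on the core of compound 2 would give a step of similar size.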